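Swapping Trifluoromethyl for Trifluoromethoxy on Two Related Cores

This account rests on a few compounds, and the source may have more. Where it says the series, first, only, none or still open, it means among the compounds named here.

Compound 1 `CC(O)(CSc1ccccc1C(F)(F)F)C(=O)Nc1cccc(S(F)(F)(F)(F)F)c1` and compound 2 `CC(O)(CSc1ccccc1OC(F)(F)F)C(=O)Nc1cccc(S(F)(F)(F)(F)F)c1` share one core and differ in a single place: trifluoromethoxy in place of trifluoromethyl on an aromatic carbon. In a functional assay on CWR22R cells (Homo sapiens) for antiproliferative activity, read by propidium iodide staining, with a stated time of 96 h (a higher number here means a weaker inhibitor, a lower number a stronger inhibitor), compound 1 gives 13200 nM and compound 2 gives 13900 nM, which amounts to a 1.1-fold higher number from compound 1 to compound 2 (0.02 log units; within the scatter). Compound 3 `CC(O)(COc1cccc(C(F)(F)F)c1)C(=O)Nc1cccc(S(F)(F)(F)(F)F)c1` is built on a different core; the difference between the two cores is not broken down here. In this assay compound 3 gives 28900 nM. Compound 4 `CC(O)(COc1cccc(OC(F)(F)F)c1)C(=O)Nc1cccc(S(F)(F)(F)(F)F)c1` has not yet been measured and differs from compound 3 as follows: trifluoromethoxy in place of trifluoromethyl on an aromatic carbon. This is the same kind of change as that from compound 1 to compound 2, though there the group sat ortho to a large group and here it sits meta to a large group. Only a small step is expected, a 1.1-fold higher number from compound 3 to compound 4 (0.03 log units; within the scatter), because a 1.1-fold higher number from compound 1 to compound 2 (0.02 log units; within the scatter). Compound 4 is therefore estimated at 31000 nM, with a likely range from 15000 nM to 65000 nM.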

Compound 4, half-maximal inhibitory concentration: 18800 nM
Compound 4: middle estimate off by 1.6-fold (0.22 log units), on the high side; measured number inside the range.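

In this assay the swap of trifluoromethyl for trifluoromethoxy gives a 1.5-fold lower number from compound 3 to compound 4 (0.19 log units; within the scatter), so on this second core the change again stays inside what repeat measurements could produce. Set side by side, the two results do not differ by more than that ordinary noise: the same change on two cores in this assay, a 1.1-fold higher number (0.02 log units; within the scatter) from compound 1 to compound 2 and a 1.5-fold lower number (0.19 log units; within the scatter) from compound 3 to compound 4, 1.6-fold (0.21 log units) apart, within the scatter of two such steps. So far the swap carries from one core to the other without a detectable effect, but this rests on only two pairs and cannot show that the true step is zero or that it would hold on a further core.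

The compounds shown leave open whether a different group at this place on the ring, such as an amine or a carboxylic acid, would move the number beyond the scatter. They also leave open what a longer chain there would do.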